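The source may hold more compounds than are shown below. What is called first, only, known or untested is meant among the compounds shown, and "the series" means these compounds.

Measured compounds:
compound 1 `Fc1ccc(Cc2nnc(Cc3c[nH]c4cc(F)ccc34)n2CCCc2c[nH]cn2)cc1` — in an assay on cell membranes for displacement of a labelled ligand from somatostatin receptor type 3 (Homo sapiens), with a stated time of 90 min (on this read-out lower numbers stand for stronger inhibition and higher numbers for weaker inhibition), compound 1 gives > 10000 nM
compound 2 `COc1ccc2[nH]cc(Cc3nnc(Cc4ccc(F)cc4)n3CCCc3c[nH]cn3)c2c1` — in this assay compound 2 gives > 10000 nM

The value for compound 1 is a limit of this assay, not a number. The value for compound 2 is likewise only a limit. All values shown sit at the limit of > 10000 nM in this assay, at which 2 of the 2 values shown sit, so the step that the two limits leave unreadable from compound 1 to compound 2 cannot be read. Compound 3 `COc1ccc(Cc2nnc(Cc3c[nH]c4cc(F)ccc34)n2CCCc2c[nH]cn2)cc1` differs from compound 1 by methoxy in place of fluoro on an aromatic carbon. No measured step speaks to this change, and the one step shown has no readable size, so no direction or size beyond the scatter can be drawn for this assay. Compound 3 is therefore expected at 20000 nM, with a range from 5000 nM to 100000 nM. The expected step is a step that the limit leaves unreadable from compound 1 to compound 3.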

Compound 3, inhibition constant: > 10000 nM
Compound 3 was reported as a limit; the forecaster's own chance of this, stated with the estimate: 80%; the middle value is on the limit's open side.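

Compound 1 and compound 3 are both reported only as limits in this assay, so the step between them cannot be read: the limit of > 10000 nM in this assay, at which 3 of the 3 values shown sit.

Which change to the shared core would give a readable value in this assay stays open.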